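This account rests on a few compounds, and the source may have more. Where it says the series, first, only, none or still open, it means among the compounds named here.

Working notes on the series. In a toxicity assay on THP-1 cells (Homo sapiens) for inhibition (a higher number here means that more compound is tolerated, a lower number that less compound is tolerated), none of the three measured compounds gives a number. Compound 1, `Cn1c(-c2ccccc2Cl)cnc1NC(=O)c1ncc[nH]1`, reaches only the limit of the assay, > 50000 nM. Compound 3, `Cn1c(-c2ccccc2)cnc1NC(=O)c1ccccc1Cl`, likewise stops at the limit, > 50000 nM. Compound 2, `COc1ccc(-c2cnc(NC(=O)c3cccc(O)c3)n2C)cc1`, stands at a different limit, > 100000 nM, which is a limit and not a measured number. Compound 2 thus sits at the limit of > 100000 nM in this assay, at which 1 of the 3 values shown sits. Compounds 1 and 3 sit at the limit of > 50000 nM in this assay, at which 2 of the 3 values shown sit. Going by the values given here, no pair among the three differs in a single place, so no step between measured compounds can be read off, and the two limits lie within the scatter of each other.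

Compound 4, `COc1ccc(-c2cnc(NC(=O)c3ccc(C#N)cc3)n2C)cc1`, has yet to be measured in this assay. It differs from compound 2 by 4-cyanophenyl in place of 3-hydroxyphenyl on a carbonyl carbon. The rest of compound 2 is kept unchanged. With all three measured values being limits, the data give no direction for the change; the expectation is a step of a number no higher from compound 2 to compound 4 (the limit leaves the size open), within the scatter, with a good chance that the result is again only a limit. On that basis compound 4 is estimated at 100000 nM in this assay, with a range from 30000 nM to 300000 nM.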

Compound 4, half-maximal cytotoxic concentration: > 100000 nM
Compound 4: no number, only a limit (the forecaster's own chance of this, stated with the estimate: 85%); the middle value sits exactly at the limit.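

Compound 2 and compound 4 both stop at the same limit in this assay, so no step between them can be read: the limit of > 100000 nM in this assay, at which 2 of the 4 values shown sit.

The compounds shown leave open whether any of them has a measurable half-maximal cytotoxic concentration in this assay, and whether 4-cyanophenyl in place of 3-hydroxyphenyl on a carbonyl carbon changes it at all.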